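Methyl for phenyl in two fused pyrimidinone-type cores

The source may report more compounds than this note shows. Statements on the series, on what has been measured and on what is new or still open speak of the compounds shown alone.

Measured compounds:
compound 1 `Cc1cc2nn(-c3ccccc3)c(N)c2c(=O)[nH]1` — 4%
compound 2 `Nc1c2c(=O)[nH]c(-c3ccccc3)cc2nn1-c1ccccc1` — 13%
compound 3 `Cc1cc2nc(-c3ccccc3)nc(N)c2c(=O)[nH]1` — 15%

All three were tested in an assay on isolated protein for inhibition of ribosomal protein S6 kinase alpha-5 (Homo sapiens), read by mobility shift assay, tested at 30 uM; a lower number here means less inhibition, a higher number more inhibition at the concentration tested (going by the name of the read-out). Compound 2 gives 13% and compound 1 gives 4%; the step of a number 9 percentage points lower from compound 2 to compound 1 (within the scatter) goes with the change (methyl in place of phenyl on an aromatic carbon). Compound 3 gives 15%; its core and the core of compound 2 differ in a way that is not broken down here, and the two values lie within the scatter of each other, as does the gap between compound 2 and compound 1.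

Compound 4 `Cc1nc(N)c2c(=O)[nH]c(C)cc2n1` is not yet measured. It arises from compound 3 by methyl in place of phenyl on an aromatic carbon. This is the same kind of change as from compound 2 to compound 1, but not the same: here the aromatic carbon belongs to a ring with 2 nitrogen and sits between two ring nitrogen atoms, meta to an amino group, whereas before it belonged to a ring with 1 nitrogen, next to the ring nitrogen. Because the earlier step of a number 9 percentage points lower from compound 2 to compound 1 (within the scatter) stayed within the scatter, a step of about a number 8 percentage points lower from compound 3 to compound 4 (within the scatter) is expected here too. Compound 4 is estimated at 7%, between -5% and 18%.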

Compound 4, a percentage reported as inhibition, at one concentration (the size of the read-out at that concentration, not a potency): 0%
For compound 4 the middle estimate is 7 percentage points above the measured one, within the range that was stated.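

In this assay, methyl in place of phenyl on an aromatic carbon gives a number 15 percentage points lower from compound 3 to compound 4 (beyond the scatter). Set beside the earlier step on the other core, the two steps cannot be told apart: the same change on two cores in this assay, a number 9 percentage points lower (within the scatter) from compound 2 to compound 1 and a number 15 percentage points lower (beyond the scatter) from compound 3 to compound 4, 6 percentage points apart, within the scatter of two such steps This is compatible with the change carrying over between these two cores, but it does not show a fixed step size, and with only one of the two steps beyond the scatter, two pairs cannot establish that replacing phenyl with methyl lowers inhibition on every core of this series.

Still open, on these data alone, is what other groups at this place, such as an amine, a carboxylic acid or a longer chain, would do on either core. Also open, as far as these compounds go, is whether a phenyl ring carrying chlorine or a methoxy group would give a reading different from that of the unsubstituted phenyl compounds, and whether any such difference would hold on both cores.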